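The compounds below may be only part of what the source reports. "The series", "measured", "known", "first", "only" and "open" are said of these compounds alone.

Compound 1 `CN(c1ccc(Oc2ncnc3sccc23)cc1)c1nccc(N2CCc3ccccc3C2)n1` is measured in a functional assay on HCT-116 cells (Homo sapiens) for inhibition, read by MTT assay, with a stated time of 72 h, tested at 20 uM (a lower number here means less inhibition, a higher number more inhibition at the concentration tested (going by the name of the read-out)), and gives 57.7%. Within the data shown here, that number is the lowest of the three so far, though neither companion is clear of it: compound 2 `CN(c1ccc(Oc2ncnc3ccsc23)cc1)c1nccc(N2CCc3ccccc3C2)n1` gives 58.3%, and compound 3 `c1cc(N2CCCCC2)nc(Nc2ccc(Oc3ncnc4ccsc34)cc2)n1` gives 61.5%. Among the measured compounds shown here, the only single-point step within the measured set, a number 0.6 percentage points higher from compound 1 to compound 2 (within the scatter), swaps one bicyclic aryl ether for an isomeric one and stays within the scatter. For the measured compounds named here, compound 3 carries a piperidin-1-yl where compound 1 carries the tetrahydroisoquinoline, but it also differs elsewhere, so no step is computed for that pair; its value sits within the scatter of compound 1 all the same.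

Compound 4 `CN(c1ccc(Oc2ncnc3sccc23)cc1)c1nccc(N2CCCC2)n1` has not yet been measured. It differs from compound 1 in one place: pyrrolidin-1-yl in place of 1,2,3,4-tetrahydroisoquinolin-2-yl on an aromatic carbon. Going by the values given here, no measured step bears directly on this change. Given that compound 3, with a smaller saturated amine, gives 61.5%, a step of no more than the scatter is expected, with a number 2.7 percentage points lower from compound 1 to compound 4 (within the scatter) near zero. In this assay compound 4 is therefore estimated at 55%, within 35% to 75%.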

Compound 4, a percentage reported as inhibition, at one concentration (the size of the read-out at that concentration, not a potency): 42.2%
For compound 4 the middle estimate is 12.8 percentage points above the measured one, and the stated range covers the measured number.
By their numbers in this assay, from the lowest: compound 4; then compounds 1, 2 and 3 (each within the scatter of the next).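

In this assay, among these compounds, the change at this position gives a number 15.5 percentage points lower from compound 1 to compound 4 (beyond the scatter), the first step beyond the scatter, so the group on this aromatic carbon of the six-membered aromatic ring with 2 nitrogen does affect the read-out. The group leaving, 1,2,3,4-tetrahydroisoquinolin-2-yl, has two rings and the group entering, pyrrolidin-1-yl, has one ring and fewer heavy atoms, while the hydrogen-bond donor and acceptor counts and the net charge stay the same. Nothing measured here explains the drop.

This one step cannot separate the loss of the six-membered aromatic ring of carbon only from the change in ring size or in total heavy atoms. A morpholin-4-yl or a benzylamino group at this position on the core of compound 1 would leave open how far the read-out follows either feature.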